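This account rests on a few compounds, and the source may have more. Where it says the series, first, only, none or still open, it means among the compounds named here.

In a physicochemical assay for lipophilicity (on this read-out lower numbers stand for lower lipophilicity and higher numbers for higher lipophilicity), three compounds have been measured so far. Compound 1 `COc1ccc2nccc(C(O)CC3CCC(/C=C/Br)CN3)c2c1` gives 1.71 and compound 3 `OC(CC1CCCCN1)C1CC=Nc2c1cccc2C(F)(F)F` gives 1.12. Compound 2 `OC(CC1CCCCN1)c1ccnc2ccccc12` gives 0.05, the lowest of the three numbers, and both of the others stand above it by more than the scatter.

Compound 4 `OC(CC1CCCCN1)c1cc(C2CCCCC2)nc2ccccc12` has not yet been measured. It departs from compound 2 in one place: cyclohexyl in place of hydrogen on an aromatic carbon. The cyclohexyl, in place of hydrogen on an aromatic carbon, sits next to the ring nitrogen. Among the compounds with values here, no measured pair in this small set differs in one place only, so no observed step can serve as a direct guide, and the expectation rests on the structural change itself. In this assay a rise well beyond the scatter is expected, and the estimated step is a number 2.25 log units higher from compound 2 to compound 4 (beyond the scatter). For compound 4 the expected value is 2.3, with an estimated range of 1.6 to 3.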

Compound 4, partition coefficient: 2.56
The estimate for compound 4 lay 0.26 log units below the measured number; measured number inside the range.
By their numbers in this assay, from the lowest: compound 2; then compound 3; then compound 1; then compound 4.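

Within the data shown here, the pair compound 2 and compound 4 gives the first change in one place alone in this set, and in this assay it is large: a number 2.51 log units higher from compound 2 to compound 4 (beyond the scatter). It shows that cyclohexyl in place of hydrogen on an aromatic carbon, next to the ring nitrogen, moves the read-out far on the shared core, although the group enters with no hydrogen-bond donors or acceptors and no net charge. No measurement shown here accounts for the size of this step.

The compounds shown leave open how the step would change with a smaller methyl, a flat phenyl ring or an open hexyl chain on the same carbon. They also leave open whether an amine or a carboxylic acid there would take the number the other way.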